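The compounds below may be only part of what the source reports. "The series", "measured", "known", "first", "only" and "open" are said of these compounds alone.

In an ADME assay on Vero 76 cells (Chlorocebus sabaeus) for cytotoxicity, read by MTT assay, with a stated time of 96 h (on this read-out higher numbers stand for lower toxicity in this test and lower numbers for higher toxicity in this test), compound 2 (`Cc1ccc(C2CC(c3ccc(Oc4ccccc4)cc3)=NN2c2ccc(S(N)(=O)=O)cc2)cc1`) gives 86000 nM and compound 1 (`Cc1ccc(C2CC(c3ccc(OCc4ccccc4)cc3)=NN2c2ccc(S(N)(=O)=O)cc2)cc1`) gives 100000 nM with the two values within the scatter of each other. Compound 3 (`NS(=O)(=O)c1ccc(N2N=C(c3ccc(Oc4ccccc4)cc3)CC2c2ccc(F)cc2)cc1`) differs from compound 2 by fluoro in place of methyl on an aromatic carbon (fluoro in place of methyl on an aromatic carbon, para to a large group). Within the data shown here, the one measured step (a 1.2-fold lower number from compound 1 to compound 2 (0.07 log units; within the scatter)) concerns another group, so it bears only indirectly, and no measured step covers this change. On that thin basis, no step beyond the scatter is expected in this assay here. The expected step is small (a 1.1-fold lower number from compound 2 to compound 3 (0.03 log units; within the scatter)). Compound 3 is expected at 80000 nM (estimated range 40000 nM to 120000 nM).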

Compound 3, half-maximal cytotoxic concentration: 25000 nM
Compound 3: the middle estimate sits 3.2-fold (0.51 log units) above what was measured; measured number outside the range, below it.
By their numbers in this assay, from the lowest: compound 3; then compounds 2 and 1 (each within the scatter of the next).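

Fluoro in place of methyl, on an aromatic carbon para to a large group, gives a step in this assay of a 3.4-fold lower number from compound 2 to compound 3 (0.54 log units; beyond the scatter) and moves the series toward higher toxicity in this test. The step on the oxygen, a 1.2-fold lower number from compound 1 to compound 2 (0.07 log units; within the scatter), stays within the scatter, so this aromatic position is the first place shown where one change moves the read-out beyond it. Nothing measured here accounts for the step.

Open, going by these compounds, is whether chloro, methoxy or an amine at this place would read like fluoro or like methyl. Also open, on these data alone, is whether 4-methylphenyl to 4-fluorophenyl gives a step of similar size with benzyl on the oxygen.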